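Aryl swap at the ring nitrogen of compound 3

The source may hold more compounds than are shown below. What is called first, only, known or untested is meant among the compounds shown, and "the series" means these compounds.

Of the compounds shown here, three sharing one core have been measured in a functional assay on PC-3 cells (Homo sapiens) for cytotoxicity, read by MTT assay, with a stated time of 72 h; a lower number here means a stronger inhibitor, a higher number a weaker inhibitor. Compound 1 `CCCCCCNc1nc(SCc2ccc(C(F)(F)F)cc2)nc2ccccc12` gives 19000 nM, compound 2 `CCCCCCCCNc1nc(SCc2ccc(C(F)(F)F)cc2)nc2ccccc12` gives 10500 nM, and compound 3 `FC(F)(F)c1ccc(CSc2nc(Nc3cccc(Br)c3)c3ccccc3n2)cc1` gives 8680 nM, the lowest number of the three. The steps that reach compound 3 are a 2.2-fold lower number from compound 1 to compound 3 (0.34 log units; beyond the scatter) and a 1.2-fold lower number from compound 2 to compound 3 (0.08 log units; within the scatter). Compound 4 `Fc1ccc(Nc2nc(SCc3ccc(C(F)(F)F)cc3)nc3ccccc23)cc1` differs from compound 3 by 4-fluorophenyl in place of 3-bromophenyl on a nitrogen on an aromatic ring. For the measured compounds named here, no measured step exchanges one aryl group for another on that nitrogen; the two steps that bear on the site are modest or within the scatter. The step of a 1.2-fold higher number from compound 3 to compound 4 (0.06 log units; within the scatter) is therefore expected to stay within the scatter, with no clear direction. Compound 4 is estimated at 10000 nM, between 4000 nM and 25000 nM.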

Compound 4, half-maximal inhibitory concentration: 7070 nM
Estimate against measurement, compound 4: 1.4-fold (0.15 log units) above; the range from low to high includes it.
By their numbers in this assay, from the lowest: compounds 4, 3, 2 and 1 (each within the scatter of the next, the first and the last beyond it).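

This first exchange of one aryl group for another on the nitrogen on an aromatic ring stays within the scatter in this assay (a 1.2-fold lower number from compound 3 to compound 4 (0.09 log units; within the scatter)). The 4-fluorophenyl group also stays within the scatter against octyl (a 1.5-fold lower number from compound 2 to compound 4 (0.17 log units; within the scatter)) but lies beyond it against hexyl (a 2.7-fold lower number from compound 1 to compound 4 (0.43 log units; beyond the scatter)), so it gives the same reading as 3-bromophenyl against each chain. No measurement shown explains these steps.

The 3-bromophenyl and 4-fluorophenyl groups differ both in the halogen and in where it sits, and the compounds shown do not separate the two. Going by these compounds, whether a phenyl ring carrying a carboxylic acid or an amine would move the number beyond the scatter remains open.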